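A methoxypyridine in place of a methylpyridine

The source may report more compounds than this note shows. Statements on the series, on what has been measured and on what is new or still open speak of the compounds shown alone.

In an ADME assay (liver) for metabolic stability, with Liver microsome (Rattus norvegicus) as the target, using microsomes and NADPH, with a stated time of 30 min, tested at 1 uM (a higher number here means faster removal of the compound, a lower number slower removal), compound 1 `COCC#Cc1cc(C(O)(C(F)(F)F)C(F)(F)F)cnc1N1CCN(S(=O)(=O)c2ccc(N)nc2)CC1` gives 399 mL.min-1.g-1, compound 2 `Nc1ccc(S(=O)(=O)N2CCN(c3ncc(C(O)(C(F)(F)F)C(F)(F)F)cc3-c3cnccc3F)CC2)cn1` gives 22 mL.min-1.g-1 and compound 3 `Cc1ccc(-c2cc(C(O)(C(F)(F)F)C(F)(F)F)cnc2N2CCN(S(=O)(=O)c3ccc(N)nc3)CC2)cn1` gives 182 mL.min-1.g-1. Compound 3 thus holds the middle place of the three. Compound 4 `COc1cncc(-c2cc(C(O)(C(F)(F)F)C(F)(F)F)cnc2N2CCN(S(=O)(=O)c3ccc(N)nc3)CC2)c1` carries 5-methoxypyridin-3-yl in place of 6-methylpyridin-3-yl on an aromatic carbon. All three measured steps change this same place. The largest is an 18-fold lower number from compound 1 to compound 2 (1.26 log units; beyond the scatter), and the smaller one is a 2.2-fold lower number from compound 1 to compound 3 (0.34 log units; beyond the scatter). The closest guide is the swap of one pyridine for another, an 8.3-fold higher number from compound 2 to compound 3 (0.92 log units; beyond the scatter), which shows that pyridines at this place can differ widely. For the measured compounds named here, no measured compound carries 5-methoxypyridin-3-yl, so the direction rests on little. Compound 2, the other pyridine, has the lower number at 22 mL.min-1.g-1, which tilts the expectation slightly downward. The expected change is small, a 1.5-fold lower number from compound 3 to compound 4 (0.18 log units; within the scatter). For compound 4 the estimate is 120 mL.min-1.g-1, with an expected range of 40 mL.min-1.g-1 to 350 mL.min-1.g-1.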

Compound 4, intrinsic clearance in microsomes: 58 mL.min-1.g-1
Estimate against measurement, compound 4: 2.1-fold (0.32 log units) above; measured number inside the range.
By their numbers in this assay, from the lowest: compound 2; then compound 4; then compound 3; then compound 1.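

In this assay, the exchange of 6-methylpyridin-3-yl for 5-methoxypyridin-3-yl gives a 3.1-fold lower number from compound 3 to compound 4 (0.50 log units; beyond the scatter), so two substituted pyridines at this place, ortho to a large group, separate by more than the usual scatter. The new pyridine does not match the lowest number: 5-methoxypyridin-3-yl in place of 4-fluoropyridin-3-yl gives a 2.6-fold higher number from compound 2 to compound 4 (0.42 log units; beyond the scatter), while its exchange for 3-methoxyprop-1-yn-1-yl gives a 6.9-fold lower number from compound 1 to compound 4 (0.84 log units; beyond the scatter), leaving all three pyridine compounds below compound 1. No measurement shown here accounts for these differences.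

The compounds shown leave open whether each substituent raises or lowers the number relative to an unsubstituted pyridin-3-yl group. Going by these compounds, how an amine or a carboxylic acid on the pyridine would read here also remains open.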